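Cyano in place of carbamoyl on the shared core

This account rests on a few compounds, and the source may have more. Where it says the series, first, only, none or still open, it means among the compounds named here.

In a functional assay on the whole organism for inhibition, with Cavia porcellus as the target (a lower number here means that less compound is needed, a higher number that more compound is needed for the effect), compound 1 `NC(=O)c1cn2cc(Br)nc(Br)c2n1` gives > 18 nM as a limit and not a number. Compound 2 `N#Cc1cn2ccncc2n1` gives > 167 nM as a limit too. Within the data shown here, compound 1 thus stands on a limit only, and the series holds no measured step. Compound 3 `N#Cc1cn2cc(Br)nc(Br)c2n1` carries cyano in place of carbamoyl on an aromatic carbon. The expected size of the change is a step that the limit leaves unreadable from compound 1 to compound 3 toward a higher number in this assay and is a loose estimate. For compound 3 the estimated value is 60 nM with an expected range from 8 nM to 500 nM as a working figure.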

Compound 3, concentration for half-maximal effect: 16 nM
Compound 3: the middle estimate sits 3.8-fold (0.57 log units) above what was measured; the range from low to high includes it.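

Among these compounds, compound 3 gives the first value in this assay that is a number and not a limit, so cyano on this aromatic carbon of the shared core yields a readable result. Cyano in place of carbamoyl gives an at least 1.1-fold lower number from compound 1 to compound 3 (0.05 log units; that floor lies within the scatter). Only this floor can be read, and the full size of the step stays open: the limit of > 18 nM in this assay, at which 1 of the 3 values shown sits.

Open, as far as these compounds go, is how an amine or a carboxylic acid at the same place would read in this assay. No step shown isolates either bromine.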